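Allyloxy for Pyrazolyl: Expected Clearance of Compound 3

This account rests on a few compounds, and the source may have more. Where it says the series, first, only, none or still open, it means among the compounds named here.

Measured compounds:
compound 1, `O=C(NNS(=O)(=O)c1ccccc1F)c1cc(F)cc(-n2cccn2)c1`, giving 18 uL/min
compound 2, `Cc1cc(-n2cccn2)cc(C(=O)NNS(=O)(=O)c2ccccc2)c1F`, giving 23 uL/min

Both numbers come from an ADME assay on microsomes from liver (Homo sapiens) for metabolic stability, read by HPLC, using NADPH, with a stated time of 60 min, tested at 1 uM, in the presence of a further agent that is not named here; a lower number here means slower removal, a higher number faster removal of the compound. In this assay compound 1 gives 18 uL/min and compound 2 gives 23 uL/min. Compound 1 holds the lowest of the two numbers, but compound 2 lies within the usual scatter of it, so the two cannot be told apart on this evidence.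

The unmeasured compound 3, `C=CCOc1cc(F)cc(C(=O)NNS(=O)(=O)c2ccccc2F)c1`, is reached from compound 1 by one change: allyloxy in place of 1H-pyrazol-1-yl on an aromatic carbon. Among the measured compounds shown here, no pair of measured compounds shares this change, so nothing in the data gives a direct reading of its size. In this assay the step of a 1.9-fold higher number from compound 1 to compound 3 (0.29 log units; within the scatter) is expected to go toward faster removal, a little beyond the scatter, though the uncertainty is wide. Compound 3 is therefore estimated at 35 uL/min in this assay, within a range from 15 uL/min to 80 uL/min.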

Compound 3, intrinsic clearance in a liver preparation (reported as CLH), per the amount of preparation that the assay uses: 138 uL/min
The estimate for compound 3 lay 3.9-fold (0.60 log units) below the measured number, outside the stated range (above it).
By their numbers in this assay, from the lowest: compounds 1 and 2 (each within the scatter of the next); then compound 3.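

The two earlier compounds both carry 1H-pyrazol-1-yl, so they gave no view of how much the group on this aromatic carbon, meta to a fluoro group, matters for removal of the compound. With allyloxy in its place, this assay shows a 7.7-fold higher number from compound 1 to compound 3 (0.88 log units; beyond the scatter), the first difference in this set that lies beyond the scatter, so this position is clearly not indifferent to what it holds, at least for this one change. The change replaces a five-membered aromatic ring with an open group holding a double bond outside aromatic rings, but nothing in the data shown bears on why the number rises.

Among the compounds shown here, the single pair does not separate the loss of the ring from the arrival of the ether oxygen or of the double bond, and a saturated propoxy chain, a methoxy group or another aromatic ring such as imidazolyl at this carbon would each divide those contributions differently. Also open, on these data alone, is whether allyloxy would give a step of similar size on the core of compound 2, which carries a methyl group and a differently placed fluoro group.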